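The compounds below may be only part of what the source reports. "The series", "measured", "known", "first", "only" and "open" are said of these compounds alone.

Four close relatives of one scaffold are compared here, all carrying a thiol-bearing acrylic acid on an indole. Compound 1 `O=C(O)/C(S)=C/c1c[nH]c2ccc(Br)cc12` carries a bromo group and in an assay on isolated protein for inhibition of Calpain-1 catalytic subunit (Sus scrofa) (on this read-out lower numbers stand for stronger inhibition and higher numbers for weaker inhibition), compound 1 gives 20 nM. Compound 3 `O=C(O)/C(S)=C/c1c[nH]c2ccc(Cl)cc12` differs from it by chloro in place of bromo on an aromatic carbon, and in this assay compound 3 gives 50 nM, so the step of a 2.5-fold higher number from compound 1 to compound 3 (0.40 log units; beyond the scatter). Compound 2 `O=C(O)/C(S)=C/c1c[nH]c2c(Br)cccc12` has the same atoms as compound 1 joined differently; the difference between the two cores is not broken down here. In this assay compound 2 gives 70 nM. Compound 4 `O=C(O)/C(S)=C/c1c[nH]c2c(Cl)cccc12` is the not yet measured partner of compound 2, differing by chloro in place of bromo on an aromatic carbon. This is the same kind of change as seen from compound 1 to compound 3, though the place differs: in compound 4 the chloro sits ortho to a fused ring and meta to a fused ring, while in compound 3 it sits meta to a fused ring and para to a fused ring. Because the earlier step of a 2.5-fold higher number from compound 1 to compound 3 (0.40 log units; beyond the scatter) weakened binding modestly, a comparable expected step a 2.3-fold higher number from compound 2 to compound 4 (0.36 log units; beyond the scatter) seems reasonable. Compound 4 is therefore estimated at 160 nM, likely between 60 nM and 400 nM.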

Compound 4, half-maximal inhibitory concentration: 90 nM
The estimate for compound 4 lay 1.8-fold (0.25 log units) above the measured number, and the stated range covers the measured number.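

On the core of compound 2, chloro in place of bromo in this assay gives a 1.3-fold higher number from compound 2 to compound 4 (0.11 log units; within the scatter), a step too small to separate from ordinary assay noise. Set beside the same swap on the core of compound 1, this step cannot be told apart from the earlier one: the same change on two cores in this assay, a 2.5-fold higher number (0.40 log units; beyond the scatter) from compound 1 to compound 3 and a 1.3-fold higher number (0.11 log units; within the scatter) from compound 2 to compound 4, 1.9-fold (0.29 log units) apart, within the scatter of two such steps. The result therefore fits the idea that this swap carries over from one of these cores to the other with a similar modest or negligible change, but it does not prove that the two steps are equal, and two pairs cannot show that the swap would behave the same way on any further core.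

Bromo and chloro are the only groups compared at these places, so it remains open how a fluoro, methyl or methoxy group would read out there. As far as these compounds go, it also remains open whether the swap would give a similar step at any other ring carbon of the shared core.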